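Working notes: aryl change on the weaker side chain

This account rests on a few compounds, and the source may have more. Where it says the series, first, only, none or still open, it means among the compounds named here.

Values in a functional assay on HT-29 cells (Homo sapiens) for inhibition, read by MTT assay, with a stated time of 72 h; a higher number here means a weaker inhibitor, a lower number a stronger inhibitor:
- compound 1 `CN(C)CCn1c(=O)c(=Cc2ccc(F)c(F)c2)s/c1=C1\C(=O)Nc2cc(F)ccc21`: 12100 nM
- compound 2 `CCN(CC)CCCn1c(=O)c(=Cc2ccc(F)c(F)c2)s/c1=C1\C(=O)Nc2cc(F)ccc21`: 28 nM
- compound 3 `COc1ccc(OC)c(C=c2s/c(=C3\C(=O)Nc4cc(F)ccc43)n(CCN(C)C)c2=O)c1`: not yet measured

Compound 1 has the higher number of the two measured compounds, which makes it the weaker inhibitor of the pair in this assay. The next change is 2,5-dimethoxyphenyl in place of 3,4-difluorophenyl on a double-bonded chain carbon bound to an aromatic carbon. Compound 3 otherwise keeps the structure of compound 1, including its side chain.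

Within the data shown here, only one measured step exists, and it lies in the side chain rather than at this place: a 430-fold lower number from compound 1 to compound 2 (2.64 log units; beyond the scatter). That large step gives neither the size nor the direction of the aryl change. Among the measured compounds shown here, it shows only that a single change can move the number far, so the range must stay wide. No step beyond the scatter is expected as the central case, with compound 1 at 12100 nM as the anchor. The estimated step is a 1.5-fold lower number from compound 1 to compound 3 (0.18 log units; within the scatter). For compound 3 the expected value in this assay is 8000 nM, with an estimated range of 1000 nM to 30000 nM.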

Compound 3, half-maximal inhibitory concentration: 4450 nM
Compound 3: the middle estimate sits 1.8-fold (0.25 log units) above what was measured; low and high end bracket the measured number.
By their numbers in this assay, from the lowest: compound 2; then compound 3; then compound 1.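

In this assay, among these compounds, the first measured change at this position, 2,5-dimethoxyphenyl in place of 3,4-difluorophenyl on a double-bonded chain carbon bound to an aromatic carbon, gives a 2.7-fold lower number from compound 1 to compound 3 (0.43 log units; beyond the scatter) and so lies beyond the usual scatter, though only modestly. The number therefore responds to the aryl group as well as to the side chain, but this step is far smaller than a 430-fold lower number from compound 1 to compound 2 (2.64 log units; beyond the scatter) in the same assay, and the dimethylamino side chain is kept throughout the aryl change. Nothing available explains the aryl step or ties it to any feature of either group.

Going by these compounds, whether the same aryl change would give a step of similar size or direction on the side chain of compound 2 remains open, as 2,5-dimethoxyphenyl appears here only with the side chain of compound 1. This single pair also cannot separate the effect of the two methoxy groups from that of losing the two fluorines, so a phenyl group carrying one methoxy group, or a pyridine at the same place, would be informative.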